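The source may report more compounds than this note shows. Statements on the series, on what has been measured and on what is new or still open speak of the compounds shown alone.

Compound 1 `CCC1(Cc2ccccc2)OS(=O)(=O)C=C1OC` and compound 2 `CCC1(Cc2ccccc2)OS(=O)(=O)C=C1OCc1ccc(OC)cc1` share one core and differ only in the group on a saturated chain carbon bound to an oxygen on an unsaturated carbon, where compound 2 carries 4-methoxyphenyl in place of hydrogen. In an ADME assay on HEL cells (Homo sapiens) for cytotoxicity, with a stated time of 3 days (a lower number here means that less compound is tolerated, a higher number that more compound is tolerated), compound 1 gives > 200000 nM, which is a limit of the assay and not a number. In this assay compound 2 gives > 200000 nM, again a limit rather than a number. The step that the two limits leave unreadable from compound 1 to compound 2 therefore cannot be read in size or direction. Compound 3 `CCC1(Cc2ccccc2)OS(=O)(=O)C=C1OCc1ccc(C(F)(F)F)cc1` is the compound still to be measured, and its change from compound 2 is trifluoromethyl in place of methoxy on an aromatic carbon. Within the data shown here, only one measured step bears on this change, and it is the unreadable one; what the two measurements do show is the limit of > 200000 nM in this assay, at which 2 of the 2 values shown sit. With no readable step to point a direction, no change beyond the scatter is expected for the step of a number no higher from compound 2 to compound 3 (the limit leaves the size open). For compound 3 the value expected in this assay is 200000 nM, with a range from 70000 nM to 500000 nM, and most likely it will again be reported only as a limit.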

Compound 3, half-maximal cytotoxic concentration: 99000 nM
The estimate for compound 3 lay 2.0-fold (0.31 log units) above the measured number, and the stated range covers the measured number.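

In this assay compound 3 gives 99000 nM, a real number rather than a limit, so a change on this aromatic carbon can bring the value within the range the assay can read. Trifluoromethyl in place of methoxy gives an at least 2.0-fold lower number from compound 2 to compound 3 (0.30 log units; that floor lies within the scatter), and because compound 2 holds only a limit, the true size of this step stays unknown and could be larger than this floor. Compound 3 is the only one of the three compounds that leaves the limit: the limit of > 200000 nM in this assay, at which 2 of the 3 values shown sit.

The compounds shown do not tell whether this reading is specific to trifluoromethyl or would also appear with a chlorine, a nitrile or a carboxylic acid at the same place. Nor do they show how an amine or a longer chain there would read in this assay.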